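Halogen swaps on the phenyl group: the step to compound 4

The source may report more compounds than this note shows. Statements on the series, on what has been measured and on what is new or still open speak of the compounds shown alone.

Three measured compounds share one core and differ only in the halogenated phenyl group on a saturated chain carbon bound to an amine nitrogen in a ring. In a functional assay on K562 cells (Homo sapiens) for cytotoxicity, read by MTT assay, with a stated time of 48 h (on this read-out higher numbers stand for weaker inhibition and lower numbers for stronger inhibition), compound 1 (`O=C(CN[C@H]1CCN(S(=O)(=O)Cc2ccccc2)C1)N1CCN(Cc2ccccc2Cl)CC1`) gives 9000 nM, compound 2 (`O=C(CN[C@H]1CCN(S(=O)(=O)Cc2ccccc2)C1)N1CCN(Cc2ccc(Cl)cc2)CC1`) gives 9200 nM and compound 3 (`O=C(CN[C@H]1CCN(S(=O)(=O)Cc2ccccc2)C1)N1CCN(Cc2cccc(F)c2)CC1`) gives 13200 nM. Compound 3 therefore stands within the scatter of both other compounds, and the three values cannot be ranked.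

The next compound is compound 4 (`O=C(CN[C@H]1CCN(S(=O)(=O)Cc2ccccc2)C1)N1CCN(Cc2ccc(Cl)cc2Cl)CC1`), with 2,4-dichlorophenyl in place of 3-fluorophenyl at the same place: 2,4-dichlorophenyl in place of 3-fluorophenyl on a saturated chain carbon bound to an amine nitrogen in a ring. For the measured compounds named here, three measured steps bear on this change, all swaps of the same group and all within the scatter: a 1.0-fold higher number from compound 1 to compound 2 (0.01 log units; within the scatter), a 1.5-fold higher number from compound 1 to compound 3 (0.17 log units; within the scatter) and a 1.4-fold higher number from compound 2 to compound 3 (0.16 log units; within the scatter). Chlorine-bearing compound 1 and compound 2 thus give values close to that of fluorine-bearing compound 3. Going by the values given here, no measured compound carries the 2,4-dichlorophenyl group, so the range below is kept wide.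

On these steps, no change beyond the scatter is expected in this assay. The estimate means a 1.4-fold lower number from compound 3 to compound 4 (0.14 log units; within the scatter), with no firm direction expected. For compound 4 the estimated value is 9500 nM, with an expected range from 5000 nM to 17000 nM.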

Compound 4, half-maximal inhibitory concentration: 4300 nM
For compound 4 the middle estimate is 2.2-fold (0.34 log units) above the measured one; the measured number lies below the stated range.
By their numbers in this assay, from the lowest: compound 4; then compounds 1, 2 and 3 (each within the scatter of the next).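

In this assay this place on the shared core gives its first change beyond the scatter, with a 3.1-fold lower number from compound 3 to compound 4 (0.49 log units; beyond the scatter) for 2,4-dichlorophenyl in place of 3-fluorophenyl, whereas the swaps among the three groups carrying one halogen all stayed within it. Chloro in place of hydrogen on an aromatic carbon yields a 2.1-fold lower number from compound 2 to compound 4 (0.33 log units; beyond the scatter) and also a 2.1-fold lower number from compound 1 to compound 4 (0.32 log units; beyond the scatter) in the same assay, so adding a chlorine to either of the two chlorophenyl groups moves the number beyond the scatter, and compound 4 is the only one of the four whose steps to all the others are beyond it. Nothing measured in the series gives a reason for these modest steps.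

As far as these compounds go, whether the gain depends on the 2,4-dichlorophenyl group itself or simply on a second halogen stays open, and other phenyl groups carrying two halogens would bear on that. Equally open, from the compounds shown here alone, is how an unsubstituted phenyl, a methoxy group or a trifluoromethyl group on the phenyl ring would compare at this place.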